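A Third Methoxy Group on the Carbonyl-Side Ring

The compounds below may be only part of what the source reports. "The series", "measured", "known", "first", "only" and "open" are said of these compounds alone.

Of the compounds shown here, two have been measured in a functional assay on KM12 cells (Homo sapiens) for cytotoxicity, read by sulforhodamine B assay, with a stated time of 48 h, tested at 100 uM; on this read-out lower numbers stand for a stronger effect and higher numbers for a weaker effect at the one concentration tested. Compound 1, with structure `COc1ccc(C(=O)/C=C/c2cc(-c3cc(OC)c(OC)c(OC)c3)n[nH]2)cc1OC`, gives -75% in this assay, the lower of the two numbers and so the stronger effect of the pair. Compound 2, with structure `COc1cc(-c2cc(/C=C/C(=O)c3ccc(F)c(F)c3)[nH]n2)cc(OC)c1OC`, gives -48% in this assay. Within the data shown here, the single step between them, a number 27 percentage points higher from compound 1 to compound 2 (beyond the scatter), shows a modest weakening when the ring on the carbonyl carbon carries fluorines instead of methoxy groups.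

Compound 3, with structure `COc1cc(C(=O)/C=C/c2cc(-c3cc(OC)c(OC)c(OC)c3)n[nH]2)cc(OC)c1OC`, differs from compound 1 by methoxy in place of hydrogen on an aromatic carbon. Among the measured compounds shown here, no measured step involves adding a methoxy group to this ring; the only step at hand, from compound 1 to compound 2, concerns a different exchange and bears on the question only loosely. Without a directly comparable step, the expectation is that compound 3 stays close to compound 1, a step estimated as a number 3 percentage points higher from compound 1 to compound 3 (within the scatter), with nothing beyond the scatter. Compound 3 is therefore estimated at -72% in this assay, within a range from -95% to -45%.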

Compound 3, a percentage reported as activity, at one concentration (the size of the read-out at that concentration, not a potency): -81%
Beside the measured number, compound 3's estimate is 9 percentage points above it; the range from low to high includes it.
By their numbers in this assay, from the lowest: compounds 3 and 1 (each within the scatter of the next); then compound 2.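

Putting a methoxy group in place of hydrogen on the carbonyl-side ring, on the aromatic carbon ortho to a methoxy group, gives a number 6 percentage points lower from compound 1 to compound 3 (within the scatter) in this assay. Among these compounds, the earlier step showed only that this ring is sensitive to exchanging its two methoxy groups for fluorines; this new step shows that the same ring can carry a third methoxy group with no change that can be told apart from the usual scatter, so compound 3 and compound 1 stand level at the one concentration tested. Nothing measured here gives a reason for this result.

On these data alone, whether this aromatic carbon would accept an amine, a carboxylic acid or a longer chain such as butoxy as readily as it accepts methoxy remains open, so one tolerated group does not yet describe the position as a whole. Also open, as far as these compounds go, is how much the other ring's methoxy groups contribute, since that ring is the same in all three compounds and their numbers therefore say nothing about it.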